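Aryl Exchange on a Shared Core: Compound 3 to Compound 4

The compounds below may be only part of what the source reports. "The series", "measured", "known", "first", "only" and "open" are said of these compounds alone.

Of the compounds shown here, three have been measured in a functional assay on BJAB cells (Homo sapiens) for antiproliferative activity, with a stated time of 4 days; on this read-out lower numbers stand for an effect already at smaller amounts and higher numbers for an effect only at larger amounts of compound. Compound 1 `CCSc1sc(-n2nc(C)c(Cc3ccccc3[N+](=O)[O-])c2C(=O)O)nc1-c1ccc(Cl)c(Cl)c1` gives 59000 nM in this assay. Compound 2 `Cc1cc(-c2c(C)nn(-c3nc(-c4ccc(Cl)c(Cl)c4)c(SC(C)C)s3)c2C(=O)O)cc(C)n1` gives 580 nM, and compound 3 `Cc1ccc(-c2c(C)nn(-c3nc(-c4ccc(Cl)c(Cl)c4)c(SC(C)C)s3)c2C(=O)O)cc1` gives 3800 nM. Compound 3 therefore stands second highest of the three numbers, nearest to compound 2 and furthest from compound 1. Within the data shown here, the only single-point step among the measured compounds is a 6.6-fold higher number from compound 2 to compound 3 (0.82 log units; beyond the scatter).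

Compound 4 `Cc1nn(-c2nc(-c3ccc(Cl)c(Cl)c3)c(SC(C)C)s2)c(C(=O)O)c1-c1cccc(Cl)c1` has not yet been measured. It differs from compound 3 by 3-chlorophenyl in place of 4-methylphenyl on an aromatic carbon. Among the measured compounds shown here, the measured step from compound 2 to compound 3 bears on the same position, since it also exchanges the aromatic ring on that carbon, and it was of modest size; no measured pair, however, exchanges one carbon-only six-membered ring for another, so the direction is uncertain. A small step, within the scatter or slightly beyond it, is expected, and the step this estimate means is a 1.3-fold lower number from compound 3 to compound 4 (0.10 log units; within the scatter). Compound 4 is estimated at 3000 nM, with a range from 800 nM to 12000 nM.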

Compound 4, half-maximal effective concentration: 13600 nM
The estimate for compound 4 lay 4.5-fold (0.66 log units) below the measured number; the measured number lies above the stated range.
By their numbers in this assay, from the lowest: compound 2; then compound 3; then compound 4; then compound 1.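

In this assay, this position responds even when one carbon-only aromatic ring replaces another: 3-chlorophenyl in place of 4-methylphenyl gives a 3.6-fold higher number from compound 3 to compound 4 (0.55 log units; beyond the scatter) even though the two groups match in heavy-atom count and in having no hydrogen-bond donors or acceptors. The exchange of 2,6-dimethylpyridin-4-yl for 3-chlorophenyl gives a 23-fold higher number from compound 2 to compound 4 (1.37 log units; beyond the scatter) and extends the earlier picture, since both carbon-only rings now stand above compound 2 on this read-out.

The compounds shown leave open whether the change from compound 3 to compound 4 follows from the chlorine, from where the substituent sits on the ring, or from losing the methyl group, and 4-chlorophenyl or 3-methylphenyl at this carbon would separate these. No available evidence accounts for these steps.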